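Aryl swap on the benzylidene arm of compound 1

The compounds below may be only part of what the source reports. "The series", "measured", "known", "first", "only" and "open" are said of these compounds alone.

Measured compounds:
compound 1 `Cc1cccc2c1N(CC(=O)O)C/C(=C\c1ccc(F)cc1)C2=O`: 22.9%
compound 2 `CCOc1ccc(/C=C2\CN(CC(=O)O)c3c(Cl)cccc3C2=O)cc1`: 59.1%
compound 3 `Cc1cccc2c1N(CC(=O)O)C/C(=C\c1ccc(N(C)C)cc1)C2=O`: 13.2%

In an assay on HL-60 cells for inhibition of glutathione S-transferase P (Homo sapiens), read by spectrophotometry, tested at 20 uM (a lower number here means less inhibition, a higher number more inhibition at the concentration tested (going by the name of the read-out)), compound 1 gives 22.9%, which is the second highest of the three numbers. Its nearest neighbour is compound 3, where the step of a number 9.7 percentage points lower from compound 1 to compound 3 (within the scatter) lies within the scatter, so the two cannot be ordered. Among the compounds with values here, compound 2, with its ethoxy group and chloro on the core, stands furthest away with 59.1%, a gap beyond the scatter; no single-point step links it to compound 1.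

Compound 4 `Cc1cccc(/C=C2\CN(CC(=O)O)c3c(C)cccc3C2=O)c1` differs from compound 1 in one place: 3-methylphenyl in place of 4-fluorophenyl on a double-bonded chain carbon bound to a double-bonded ring carbon. Within the data shown here, the only measured step at this position, the one from compound 1 to compound 3, was within the scatter, and no measured pair shows a methyl entering there. The change from a fluoro to a methyl on the aryl ring is therefore expected to leave this assay essentially unchanged, with no step beyond the scatter. The estimate for compound 4 is 25%, within a range of 10% to 45%, so that the expected step of a number 2.1 percentage points higher from compound 1 to compound 4 (within the scatter) stays inside the usual scatter.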

Compound 4, a percentage reported as inhibition, at one concentration (the size of the read-out at that concentration, not a potency): 39.1%
Compound 4: the middle estimate sits 14.1 percentage points below what was measured; the range from low to high includes it.
By their numbers in this assay, from the lowest: compounds 3 and 1 (each within the scatter of the next); then compound 4; then compound 2.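

Within the data shown here, the swap to 3-methylphenyl gives a number 16.2 percentage points higher from compound 1 to compound 4 (beyond the scatter) in this assay and is the first step at this position to pass the scatter, whereas a number 9.7 percentage points lower from compound 1 to compound 3 (within the scatter) did not, so the aryl group on this double-bonded chain carbon can move the read-out. The leaving and entering groups both hold 7 heavy atoms and neither has any hydrogen-bond donors or acceptors, so those counts do not separate them. Nothing available accounts for the size of this step.

From the compounds shown here alone, whether the methyl itself or its place on the aryl ring carries the step stays open, since both differ in this one swap. Also open, going by these compounds, is how a methoxy group or a nitrile on that aryl ring would read in this assay on the core of compound 1.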